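The compounds below may be only part of what the source reports. "The series", "measured", "known", "first", "only" and "open" are said of these compounds alone.

Measured compounds:
compound 1, `O=C(CN1CCN(c2nnc(Cc3ccccc3)c3ccccc23)CC1)Nc1cccc(F)c1` — 3730 nM in a functional assay on MDA-MB-231 cells (Homo sapiens) for cytotoxicity, read by MTT assay, with a stated time of 72 h; a lower number here means a stronger inhibitor, a higher number a weaker inhibitor
compound 2, `O=C(CN1CCN(c2nnc(Cc3ccccc3)c3ccccc23)CC1)Nc1c(F)cccc1F` — 5490 nM in this assay

Compound 3, `Cc1cccc(Cl)c1NC(=O)CN1CCN(c2nnc(Cc3ccccc3)c3ccccc23)CC1`, is not yet measured in this assay.

Among the measured compounds shown here, compound 2 stands at one end of the two numbers, with compound 1 its only neighbour. The step between them, a 1.5-fold higher number from compound 1 to compound 2 (0.17 log units; within the scatter), is within the scatter, so the two values cannot be told apart on these data. The change from compound 2 to compound 3 is 2-chloro-6-methylphenyl in place of 2,6-difluorophenyl on an amide-type nitrogen. For the measured compounds named here, the only measured step that bears on it is a 1.5-fold higher number from compound 1 to compound 2 (0.17 log units; within the scatter), which also exchanges one fluorinated phenyl for another on the amide-type nitrogen and produced no movement beyond the scatter. No measured pair exchanges fluorine for chlorine or methyl on that ring, so the effect of this particular swap is not shown. Going by the values given here, on the one step available, the expectation for compound 3 in this assay is a value close to that of compound 2, with no step beyond the scatter: a 1.1-fold lower number from compound 2 to compound 3 (0.04 log units; within the scatter). The estimate for compound 3 is therefore 5000 nM, expected to lie between 2000 nM and 14000 nM.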

Compound 3, half-maximal inhibitory concentration: 3920 nM
Estimate against measurement, compound 3: 1.3-fold (0.11 log units) above; measured number inside the range.
By their numbers in this assay, from the lowest: compounds 1, 3 and 2 (each within the scatter of the next).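

In this assay the 2-chloro-6-methylphenyl group takes the place of 2,6-difluorophenyl on the amide-type nitrogen (a 1.4-fold lower number from compound 2 to compound 3 (0.15 log units; within the scatter)), and the comparison with 3-fluorophenyl at the same place reads the same way (a 1.1-fold higher number from compound 1 to compound 3 (0.02 log units; within the scatter)). The earlier compounds shown here carried only fluorinated phenyl groups here, whereas this result extends the comparison to a ring bearing chlorine and methyl in place of fluorine, and compounds 1, 2 and 3 still cannot be told apart. Among these three compounds, then, the measured number does not separate the aryl groups on this nitrogen, and nothing in the data offers an explanation for the closeness of their values.

On these data alone, all three groups are substituted phenyl rings, so it remains open whether an unsubstituted phenyl, a pyridine, or a phenyl ring carrying an amine or a carboxylic acid would give a step beyond the scatter. As far as these compounds go, it is equally open whether a longer chain in place of the aryl group on this nitrogen, or any change elsewhere on the shared core, would move the number in this assay.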